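From Compound 3 to Compound 4: An Untested Change

The source may hold more compounds than are shown below. What is called first, only, known or untested is meant among the compounds shown, and "the series" means these compounds.

Measured compounds:
compound 1 `O=C(Nc1cccc(-n2cc(-c3ccncc3)c(-c3cc(O)cc(Cl)c3)n2)c1)Nc1ccc(Cl)c(C(F)(F)F)c1`: 2080 nM
compound 2 `O=C(Nc1cccc(-n2cc(-c3ccncc3)c(-c3cc(O)cc(Cl)c3)n2)c1)Nc1ccc(Cl)c(Cl)c1`: 1710 nM
compound 3 `COc1cc(Cl)cc(-c2nn(-c3cccc(NC(=O)Nc4ccc(Cl)c(Cl)c4)c3)cc2-c2ccncc2)c1`: 1740 nM

These three compounds were tested in a functional assay on MDA-MB-468 cells (Homo sapiens) for inhibition, read by sulforhodamine B assay, with a stated time of 48 h; on this read-out higher numbers stand for weaker inhibition and lower numbers for stronger inhibition. Their numbers sit close together: the step of a 1.2-fold lower number from compound 1 to compound 2 (0.09 log units; within the scatter) and the step of a 1.0-fold higher number from compound 2 to compound 3 (0.01 log units; within the scatter) are both within the scatter of the method, so the three compounds cannot be told apart on this read-out. Compound 3 stands second highest of the three numbers, with compound 2 nearest and compound 1 furthest, and both gaps are within the scatter.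

Compound 4 `COc1cc(Cl)cc(-c2nn(-c3cccc(NC(=O)c4cccc(C(F)(F)F)c4)c3)cc2-c2ccncc2)c1` has not been measured. It differs from compound 3 in one place: 3-(trifluoromethyl)phenyl in place of (3,4-dichlorophenyl)amino on a carbonyl carbon The two measured steps do not bear on this change. One swapped chloro for trifluoromethyl on an aromatic carbon, the other put methyl in place of hydrogen on an oxygen on an aromatic ring; neither touched the (3,4-dichlorophenyl)amino on the carbonyl carbon, and neither removed a hydrogen-bond donor. The expectation therefore rests on the shared core and on caution. The expected step is a 2.0-fold higher number from compound 3 to compound 4 (0.30 log units; within the scatter), a moderate weakening in this assay, with the possibility that nothing beyond the scatter happens. Compound 4 is estimated at 3500 nM, within a range from 1000 nM to 12000 nM.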

Compound 4, half-maximal inhibitory concentration: 4260 nM
The estimate for compound 4 lay 1.2-fold (0.09 log units) below the measured number; the range from low to high includes it.
By their numbers in this assay, from the lowest: compounds 2, 3 and 1 (each within the scatter of the next); then compound 4.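

In this assay, putting 3-(trifluoromethyl)phenyl in place of (3,4-dichlorophenyl)amino on the carbonyl carbon gives a 2.4-fold higher number from compound 3 to compound 4 (0.39 log units; beyond the scatter) and is the only step shown that lies beyond the scatter, so this position responds on this read-out in a way that the earlier, smaller edits did not reveal. The earlier steps shown here left the (3,4-dichlorophenyl)amino group in place or kept an amino link at the carbonyl carbon, whereas this change removes that link and its hydrogen-bond donor and also replaces the two chlorines with a trifluoromethyl group. Nothing given here explains the weaker inhibition of compound 4.

The compounds shown do not separate the effect of removing the amino nitrogen from that of changing the groups on the aromatic ring, and (3-(trifluoromethyl)phenyl)amino on the same carbonyl carbon would bear directly on that question. From the compounds shown here alone, how this position responds to quite different groups, such as an aliphatic amine or a carboxylic acid on the aromatic ring, also remains open.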